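The source may report more compounds than this note shows. Statements on the series, on what has been measured and on what is new or still open speak of the compounds shown alone.

Measured compounds:
Compound 1 `O=[N+]([O-])c1ccc(NC(=S)NCCNS(=O)(=O)c2ccc(-c3ccccc3OCc3ccccc3)s2)cc1`, which in a functional assay on HeLa cells (Homo sapiens) for inhibition, read by CCK-8 assay, with a stated time of 48 h (on this read-out higher numbers stand for weaker inhibition and lower numbers for stronger inhibition), gives 7100 nM.
Compound 2 `O=C(NCCNS(=O)(=O)c1ccc(-c2ccccc2OCc2ccccc2)s1)Nc1cccc([N+](=O)[O-])c1`, for which this assay reports only a limit, > 20000 nM.

Compound 2 thus stands at the weak end of the two results shown, without an exact value. Compound 3 `O=S(=O)(NCCNC(=S)Nc1ccc(Cl)cc1)c1ccc(-c2ccccc2OCc2ccccc2)s1` differs from compound 2 in one place: a group of 10 heavy atoms (7 carbon, 1 nitrogen, 1 sulfur, 1 chlorine; one six-membered aromatic ring of carbon only) in place of a group of 12 heavy atoms (7 carbon, 2 nitrogen, 3 oxygen; one six-membered aromatic ring of carbon only), on an amine nitrogen. Among the compounds with values here, one measured step bears on part of this change: an at least 2.8-fold higher number from compound 1 to compound 2 (0.44 log units; beyond the scatter). Within the data shown here, that step replaced a thiocarbonyl with a carbonyl; compound 3 brings the thiocarbonyl back, and also swaps the nitro group for chlorine, a swap with no measured counterpart here. Compound 3 is therefore expected to give a lower number than the limit of compound 2, a step of an at least 2.5-fold lower number from compound 2 to compound 3 (0.39 log units; beyond the scatter). Compound 3 is estimated at 8000 nM, with a range from 3000 nM to 25000 nM.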

Compound 3, half-maximal inhibitory concentration: 7000 nM
Compound 3: middle estimate off by 1.1-fold (0.06 log units), on the high side; the range from low to high includes it.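

In this assay, the new result shows that on the thiocarbonyl series this aromatic carbon accepts chloro in place of nitro with no change that can be read: a 1.0-fold lower number from compound 1 to compound 3 (0.01 log units; within the scatter). The second step, an at least 2.8-fold lower number from compound 2 to compound 3 (0.45 log units; beyond the scatter), covers more than one difference, as it also exchanges the carbonyl for a thiocarbonyl, and it points the same way as the earlier step away from the thiocarbonyl. Compound 2 has only a limit: the limit of > 20000 nM in this assay, at which 1 of the 3 values shown sits.

A carbonyl compound carrying chloro would be needed to separate the carbonyl change from the rest of this step. On these data alone, how a methoxy or trifluoromethyl group on the aromatic ring, or a longer chain in place of the present one, would read in this assay stays open.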